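A bromo group on a very potent growth inhibitor

The compounds below may be only part of what the source reports. "The series", "measured", "known", "first", "only" and "open" are said of these compounds alone.

Measured in a functional assay on MCF7 cells (Homo sapiens) for inhibition, read by sulforhodamine B assay, with a stated time of 48 h; on this read-out lower numbers stand for stronger inhibition of growth and higher numbers for weaker inhibition of growth:
Compound 1 `N#CCC1=NN=C(c2ccc(Br)cc2)C(CC(=O)c2ccc([N+](=O)[O-])cc2)O1`: 32000 nM
Compound 2 `N#CCC1=NN=C(c2ccc([N+](=O)[O-])cc2)CO1`: 1 nM

Compound 1 stands at 32000 nM and compound 2 holds the lower of these two numbers at 1 nM. The gap between the two lies far beyond the usual scatter. Compound 3 `N#CCC1=NN=C(c2ccc([N+](=O)[O-])cc2)C(Br)O1` departs from compound 2 by a single change: bromo in place of hydrogen on a saturated ring carbon. Among the compounds with values here, no measured pair shows this change alone, because compound 1 differs from compound 2 in more than one place, so the expectation is uncertain. With compound 2 at 1 nM, there is little room for a lower number, so weaker growth inhibition seems more likely. In this assay the expected change is a 40-fold higher number from compound 2 to compound 3 (1.60 log units; beyond the scatter), beyond the scatter but well short of the gap to compound 1. Compound 3 is estimated at 40 nM, with an expected range of 2 nM to 3000 nM.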

Compound 3, concentration for 50% growth inhibition: 10600 nM
The estimate for compound 3 lay 270-fold (2.42 log units) below the measured number, outside the stated range (above it).
By their numbers in this assay, from the lowest: compound 2; then compound 3; then compound 1.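

In this assay, swapping hydrogen for bromo on this saturated ring carbon, next to the ring oxygen, gives an 11000-fold higher number from compound 2 to compound 3 (4.03 log units; beyond the scatter), a large step beyond the scatter. Compound 1 differs from compound 2 in more than one place and could not isolate any single change, whereas this pair shows that one added bromine atom is enough on its own to turn a very strong growth inhibitor into a far weaker one. Nothing in the available data accounts for the size of this step.

On these data alone, what remains open is whether this carbon accepts anything other than hydrogen. A fluoro group, a methyl group, a hydroxyl group or an amine here could give a number close to that of compound 2, close to that of compound 3, or somewhere else entirely.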